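The source may hold more compounds than are shown below. What is called first, only, known or untested is meant among the compounds shown, and "the series" means these compounds.

Compound 1 `CC(C)C(c1ncco1)c1ccc(-c2ccc3cccc(F)c3c2)[nH]c1=O`: 0.0983 h
Compound 2 `CCn1ncc2c(F)cc(-c3ccc(C(CC)(CC)c4nncn4C)c(=O)[nH]3)cc21`: > 3 h

Both readings come from an ADME assay on microsomes from liver (Rattus norvegicus) for metabolic stability; on this read-out lower numbers stand for a shorter-lived compound and higher numbers for a longer-lived compound. In this assay compound 1 gives 0.0983 h. For compound 2 the reading is a limit of the assay, > 3 h. For the measured compounds named here, compound 1 thus holds the only plain number in this set. The remaining value is the limit of > 3 h in this assay, at which 1 of the 2 values shown sits. Going by the values given here, no two measured compounds differ in just one place, so no measured step is available to lean on.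

Compound 3 `CC(C)C(c1ccc(-c2ccc3cccc(F)c3c2)[nH]c1=O)N1CCN/C1=N\C#N` has not yet been measured in this assay. It differs from compound 1 in one place: a group of 8 heavy atoms (4 carbon, 4 nitrogen; one five-membered non-aromatic ring with 2 hetero atoms) in place of a group of 5 heavy atoms (3 carbon, 1 nitrogen, 1 oxygen; one five-membered aromatic ring with 2 hetero atoms), on a saturated chain carbon bound to an aromatic carbon and a saturated chain carbon. Among the compounds with values here, with no measured step of this kind to compare, the size of the change is open. A moderate step towards a longer-lived compound is expected, a 2.0-fold higher number from compound 1 to compound 3 (0.31 log units; beyond the scatter), though a shift that stays within the usual scatter would not be surprising either. Compound 3 is therefore estimated at 0.2 h, with a range from 0.07 h to 0.6 h.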

Compound 3, half-life: 0.327 h
The estimate for compound 3 lay 1.6-fold (0.21 log units) below the measured number; measured number inside the range.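

On a saturated chain carbon bound to an aromatic carbon and a saturated chain carbon, replacing the 1,3-oxazol-2-yl group with a group of 8 heavy atoms built on a five-membered non-aromatic ring changes the reading in this assay and gives a 3.3-fold higher number from compound 1 to compound 3 (0.52 log units; beyond the scatter). For the compounds shown here, this is the first measured step in the set, and it shows that the read-out responds to the group at this position while the rest of compound 1 stays unchanged. The entering group differs from the leaving one in size, ring aromaticity and hydrogen-bond donor count, but this single step cannot separate those features, and nothing shown accounts for the change.

As far as these compounds go, it remains open whether a simple primary amine or a carboxylic acid at this position would move the half-life in the same direction as the group in compound 3. From the compounds shown here alone, it is equally open whether an open-chain cyanoguanidine would match the ring in compound 3, or whether the same exchange would give a similar step on a different core.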